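A few compounds are considered here, and "the series" means these few. Any claim that something is new, unique, unknown or untested is made for them only; others in the source may bear on it.

In an assay for binding affinity to adenosine receptor A1 (Bos taurus) (on this read-out lower numbers stand for stronger inhibition and higher numbers for weaker inhibition), the three compounds measured so far gave the following numbers:

compound 1 `CCc1ccc(-c2nc3c(=O)n(C)c(=O)n(C)c3[nH]2)cc1` gives 0.8 nM
compound 2 `Cc1ccc(-c2nc3c(=O)n(C)c(=O)n(C)c3[nH]2)cc1` gives 0.8 nM
compound 3 `Cn1c(=O)c2nc(-c3ccc(-c4ccccc4)cc3)[nH]c2n(C)c1=O` gives 3.5 nM

Compound 3 has the highest number of the three, that is, the weakest binding. Its two neighbours tell the same story: the step of a 4.4-fold higher number from compound 1 to compound 3 (0.64 log units; beyond the scatter) and the step of a 4.4-fold higher number from compound 2 to compound 3 (0.64 log units; beyond the scatter) both show that putting a phenyl where a small alkyl group stood on the outer ring raised the number by a modest but real amount, while the step of no change at the digits printed from compound 1 to compound 2 (within the scatter) shows that swapping one small alkyl group for another made no difference.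

Compound 4 `CCOc1ccc(-c2nc3c(=O)n(C)c(=O)n(C)c3[nH]2)cc1` is the next structure, and it differs from compound 3 in one place:

ethoxy in place of phenyl on an aromatic carbon

The change therefore removes the phenyl again and puts a small chain in its place, this time one carrying an oxygen. The two steps that bear on it are the ones that introduced the phenyl, each of modest size and each raising the number. Running that change backwards should lower the number by about as much, and the ethoxy is expected to behave like the small alkyl groups of compound 1 and compound 2 rather than like the phenyl. Compound 4 is thus expected to bind more strongly than compound 3, with an estimated step of a 2.9-fold lower number from compound 3 to compound 4 (0.46 log units; beyond the scatter) in this assay. The estimate for compound 4 is 1.2 nM, with a range from 0.4 nM to 4 nM.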

Compound 4, half-maximal inhibitory concentration: 2 nM
For compound 4 the middle estimate is 1.7-fold (0.22 log units) below the measured one, and the stated range covers the measured number.
By their numbers in this assay, from the lowest: compounds 1 and 2 (each within the scatter of the next); then compounds 4 and 3 (each within the scatter of the next).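

In this assay, ethoxy does not separate clearly from phenyl at this position. The step of a 1.8-fold lower number from compound 3 to compound 4 (0.24 log units; within the scatter) stays within the usual scatter, even though ethoxy brings 3 heavy atoms and no ring where phenyl had 6 heavy atoms and a ring. Against the small alkyl groups the picture is different, with a 2.5-fold higher number from compound 2 to compound 4 (0.40 log units; beyond the scatter) when ethoxy replaces methyl and a 2.5-fold higher number from compound 1 to compound 4 (0.40 log units; beyond the scatter) when ethoxy replaces ethyl, so a short chain here does not automatically match methyl and ethyl, as the single no-change step between compound 1 and compound 2 might have suggested.

On these data alone, it remains open whether the oxygen or the length of the chain sets ethoxy apart from ethyl, and a methoxy, a hydroxyl, an amine or a longer chain at the same place would be the natural groups to compare. No measurement available here says why ethoxy falls where it does.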